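This account rests on a few compounds, and the source may have more. Where it says the series, first, only, none or still open, it means among the compounds named here.

Measured compounds:
Compound 1 `O=C(c1ccc(-c2nc(CS(=O)(=O)c3cccs3)no2)s1)C(F)(F)F` gives 520 nM in an assay on isolated protein for inhibition of protein deacetylase HDAC6 (Homo sapiens); on this read-out lower numbers stand for stronger inhibition and higher numbers for weaker inhibition.
Compound 2 `Cc1ccc(-c2noc(-c3ccc(C(=O)C(F)(F)F)s3)n2)cc1` gives 860 nM in this assay.
Compound 3 `O=C(c1ccc(-c2nc(-c3ccc(F)cc3F)no2)s1)C(F)(F)F` gives 580 nM in this assay.

Compound 3 stands second of the three numbers in this assay, with compound 1 nearest and compound 2 furthest, and both gaps fall within the usual scatter of repeated measurements, so no ordering among the three can be claimed.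

Compound 4 `O=C(c1ccc(-c2nc(Cc3cccs3)no2)s1)C(F)(F)F` is reached from compound 3 by one change: (thiophen-2-yl)methyl in place of 2,4-difluorophenyl on an aromatic carbon.

Going by the values given here, only one measured step bears on this change, the one in which one aromatic group replaced another on the same carbon: a 1.5-fold lower number from compound 2 to compound 3 (0.17 log units; within the scatter). Compound 1 carries a substituted (thiophen-2-yl)methyl group at this position and shows a value close to that of compound 3. Taken together, these data suggest that exchanging the group on this carbon leaves the number largely where it is. For compound 4 the expected step is a 1.0-fold higher number from compound 3 to compound 4 (0.01 log units; within the scatter). Compound 4 is estimated at 600 nM, with a range of 250 nM to 1400 nM.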

Compound 4, half-maximal inhibitory concentration: 170 nM
For compound 4 the middle estimate is 3.5-fold (0.55 log units) above the measured one; measured number outside the range, below it.
By their numbers in this assay, from the lowest: compound 4; then compounds 1, 3 and 2 (each within the scatter of the next).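

In this assay, the group on this carbon turns out to matter: (thiophen-2-yl)methyl in place of 2,4-difluorophenyl gives a 3.4-fold lower number from compound 3 to compound 4 (0.53 log units; beyond the scatter), and in place of 4-methylphenyl it gives a 5.1-fold lower number from compound 2 to compound 4 (0.70 log units; beyond the scatter), both beyond the scatter, whereas the earlier exchange between the two phenyl groups stayed within it. The sulfonyl link matters too: removing it from the chain, with thiophen-2-yl in place of (thiophen-2-yl)sulfonyl, gives a 3.1-fold lower number from compound 1 to compound 4 (0.49 log units; beyond the scatter), so a thiophene on a chain carbon does not by itself fix the number. No measurement here accounts for these steps.

Going by these compounds, it remains open whether the saturated chain carbon or the thiophene ring carries the gain, a question that a benzyl group or a thiophen-2-yl attached directly to the ring could separate. On these data alone, how a longer chain such as 2-(thiophen-2-yl)ethyl, or an amine on the chain carbon, would read also stays unknown.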